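A few compounds are considered here, and "the series" means these few. Any claim that something is new, unique, unknown or untested is made for them only; others in the source may bear on it.

Three compounds have numbers in an assay on cells for inhibition of Palmitoleoyl-protein carboxylesterase NOTUM variant C330S (Homo sapiens), read by fluorescence, with a stated time of 40 min; a higher number here means a weaker inhibitor, a lower number a stronger inhibitor. Compound 1 `O=C(O)C1CCN(c2ccccc2)C1` gives 48000 nM. Within the data shown here, compound 2 `O=C(O)C1CCN(c2ccccc2F)C1` gives 11000 nM, and the step of a 4.4-fold lower number from compound 1 to compound 2 (0.64 log units; beyond the scatter) is the only one-place step among the measured compounds. Compound 3 `Cc1cc(C(=O)O)c(C)n1-c1ccc(F)cc1` gives 1900 nM, the lowest of the three numbers; compound 2 stands nearest to it and compound 1 furthest, both gaps beyond the scatter. Among the measured compounds shown here, compound 3 carries a different core from compounds 1 and 2, so no measured step connects it to them directly.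

Compound 4 `Cc1cc(C(=O)O)c(C)n1-c1ccc(Cl)cc1` is not yet measured in this assay. It differs from compound 3 in one place: chloro in place of fluoro on an aromatic carbon. For the measured compounds named here, no measured step exchanges fluoro for chloro. Going by the values given here, the one step on record, a 4.4-fold lower number from compound 1 to compound 2 (0.64 log units; beyond the scatter), concerns fluoro in place of hydrogen on another core and at another place, so it bears on the present change only loosely and gives no direction for a swap between two substituents. With nothing in the measured compounds to separate chloro from fluoro, the change is expected to stay near the value of compound 3, with a step of a 1.3-fold lower number from compound 3 to compound 4 (0.10 log units; within the scatter) that may well fall within the scatter. Compound 4 is therefore expected to give 1500 nM in this assay, with a range from 500 nM to 4500 nM.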

Compound 4, half-maximal inhibitory concentration: 860 nM
Compound 4: middle estimate off by 1.7-fold (0.24 log units), on the high side; the range from low to high includes it.
By their numbers in this assay, from the lowest: compound 4; then compound 3; then compound 2; then compound 1.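

In this assay, the exchange of fluoro for chloro on an aromatic carbon of the six-membered aromatic ring, para to a large group, gives a 2.2-fold lower number from compound 3 to compound 4 (0.34 log units; beyond the scatter), a modest change but one that shows the identity of the halogen at this place can be read in this assay. Among these compounds, the earlier compounds offered only fluoro in place of hydrogen, on another core and at another place, so this is the first step within the shared core of compound 3 and compound 4 and the first between two substituents at this position. Nothing on hand gives a reason for the change, so this single step stands as an observation about one pair of compounds and not as a trend.

With only two halogens at this place, neither the parent carrying hydrogen there nor a bromo, methyl, methoxy or trifluoromethyl group is available to show how far the trend in substituents extends. Also open, from the compounds shown here alone, is whether the carboxylic acid on the shared core can give way to an amide or a nitrile, and whether chloro keeps its step in such a compound.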